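Fluoro for chloro on the aromatic carbon: compound 4

The source may report more compounds than this note shows. Statements on the series, on what has been measured and on what is new or still open speak of the compounds shown alone.

Measured so far in a functional assay on CHO cells for positive allosteric modulation of metabotropic glutamate receptor 2 (Homo sapiens), read by scintillation counting and GTPgammaS binding, with a stated time of 30 min; a lower number here means a smaller maximal response, a higher number a larger maximal response:
compound 1 `CCCCn1ccc(-c2ccc(Oc3ccnc(C)c3)cc2)c(C#N)c1=O` gives 243%
compound 2 `CCCCn1ccc(-c2ccc(Oc3ccnc(C)c3)c(Cl)c2)c(C#N)c1=O` gives 245%
compound 3 `CCCCn1ccc(-c2ccc(Oc3ccc(C)nc3C)c(Cl)c2)c(C#N)c1=O` gives 231%

Compound 2 stands highest of the three numbers in this assay; its nearest neighbour is compound 1 and its furthest is compound 3. The step of a number 2 percentage points higher from compound 1 to compound 2 (within the scatter) lies within the scatter, so the two values cannot be ordered. The step of a number 14 percentage points lower from compound 2 to compound 3 (beyond the scatter) is modest and beyond the scatter.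

Compound 4 `CCCCn1ccc(-c2ccc(Oc3ccnc(C)c3)c(F)c2)c(C#N)c1=O` has not yet been measured. It differs from compound 2 as fluoro in place of chloro on an aromatic carbon. For the measured compounds named here, the only measured step that touches this carbon is a number 2 percentage points higher from compound 1 to compound 2 (within the scatter), chloro in place of hydrogen, which stayed within the scatter. Going by the values given here, no step with fluoro at any position has been measured, so nothing distinguishes fluoro from chloro or hydrogen here. On that basis no step beyond the scatter is expected in this assay for compound 4, in either direction. The estimated step is a number 2 percentage points lower from compound 2 to compound 4 (within the scatter). Compound 4 is therefore expected to give about 243% in this assay, between 225% and 260%.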

Compound 4, largest response reached (Emax), in percent of the reference or control that the assay uses: 233%
The estimate for compound 4 lay 10 percentage points above the measured number; low and high end bracket the measured number.
By their numbers in this assay, from the lowest: compounds 3, 4, 1 and 2 (each within the scatter of the next, the first and the last beyond it).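

In this assay, the aromatic carbon ortho to a (2-methylpyridin-4-yl)oxy group now shows some sensitivity to which halogen it carries: a number 12 percentage points lower from compound 2 to compound 4 (beyond the scatter) is a modest step, whereas the earlier chloro-for-hydrogen change gave only a number 2 percentage points higher from compound 1 to compound 2 (within the scatter) and did not leave the scatter. Fluoro in place of hydrogen gives a number 10 percentage points lower from compound 1 to compound 4 (within the scatter), so hydrogen cannot be separated from either halogen at this position, although fluoro and chloro can be separated from each other. Nothing available bears on the reason for the gap between fluoro and chloro.

From the compounds shown here alone, it remains open whether the same gap appears with the 2,6-dimethylpyridin-3-yl group of compound 3 on the oxygen. Also open, going by these compounds, is how a methoxy or trifluoromethyl group would behave on this aromatic carbon.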